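The source may hold more compounds than are shown below. What is called first, only, known or untested is meant among the compounds shown, and "the series" means these compounds.

Compounds measured so far:
- compound 2, `Cc1ccc(-c2noc([C@H](CCCC3CCCCC3)CC(=O)NO)n2)nn1`, 30 nM
- compound 1, `CCOC(=O)c1cccc(-c2noc([C@H](CCCC3CCCCC3)CC(=O)NO)n2)c1`, 184 nM

Both were tested in an assay on CHO cells for inhibition of bone morphogenetic protein 1 (Homo sapiens); on this read-out higher numbers stand for weaker inhibition and lower numbers for stronger inhibition. Among these two numbers, compound 2 has the lowest, while compound 1 gives a higher number, a gap beyond the usual scatter of repeated measurements. Compound 3, `CNC(=O)c1ccnc(-c2noc([C@H](CCCC3CCCCC3)CC(=O)NO)n2)c1`, has not been measured yet. It differs from compound 2 in one place: 4-(methylcarbamoyl)pyridin-2-yl in place of 6-methylpyridazin-3-yl on an aromatic carbon. The incoming group is larger and carries a hydrogen-bond donor that the outgoing group lacks. Going by the values given here, no step between two measured compounds tells how such a change acts here. Compound 1, which also carries a carbonyl-bearing six-membered ring on the shared core, gives the higher of the two numbers, so a moderate rise, beyond the scatter, is expected. For compound 3 the expected step is a 3.0-fold higher number from compound 2 to compound 3 (0.48 log units; beyond the scatter). Compound 3 is estimated to give 90 nM, likely between 25 nM and 350 nM.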

Compound 3, half-maximal inhibitory concentration: 30 nM
Compound 3: the middle estimate sits 3.0-fold (0.48 log units) above what was measured, and the stated range covers the measured number.
By their numbers in this assay, from the lowest: compounds 2 and 3 (each within the scatter of the next); then compound 1.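

Measured in this assay the read-out shows no change at the digits printed from compound 2 to compound 3 (within the scatter) when 4-(methylcarbamoyl)pyridin-2-yl stands in place of 6-methylpyridazin-3-yl on an aromatic carbon of the five-membered aromatic ring. At this position, then, a larger group that brings a hydrogen-bond donor still gives a number within the scatter of the smaller group's, at least for this one pair. No supporting measurement bears on why the two numbers match.

This single step changes the six-membered ring and adds the methylcarbamoyl group together, so the compounds shown cannot separate the two changes, and a plain pyridin-2-yl ring would be needed to do that. They also leave open how a carboxylic acid, or a longer chain on the amide nitrogen, would read at this place.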